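The source may report more compounds than this note shows. Statements on the series, on what has been measured and on what is new or still open speak of the compounds shown alone.

In a physicochemical assay for solubility, using the shake flask method, in simulated intestinal fluid, measured as kinetic solubility, with a stated time of 2 h, at 25 degrees C, at pH 6.5 (a lower number here means a less soluble compound, a higher number a more soluble compound), compound 1 `Cc1nc(C(=O)O)c(N)c2c1C(=O)N(Cc1ccccc1)C2=O` gives 177000 nM. Compound 2 `CCCOC(=O)c1nc(C)c2c(c1N)C(=O)N(Cc1ccccc1)C2=O` gives < 5000 nM, which is a limit of the assay and not a number. Between them lies an at least 35-fold lower number from compound 1 to compound 2 (1.54 log units; beyond the scatter), a large step beyond the scatter. That step ends at the limit of < 5000 nM in this assay, at which 1 of the 2 values shown sits. Compound 3 `Cc1nc(C(N)=O)c(N)c2c1C(=O)N(Cc1ccccc1)C2=O` has amino in place of propoxy on a carbonyl carbon, and the difference from compound 2 is amino in place of propoxy on a carbonyl carbon. Going by the values given here, only one measured step bears on this change, and it touches the same carbonyl, though a different group takes the place of propoxy here. Compound 3 loses the propyl chain whose entry gave an at least 35-fold lower number from compound 1 to compound 2 (1.54 log units; beyond the scatter), so a higher number in this assay is expected, but a smaller move than that one. The expected change is an at least 3.0-fold higher number from compound 2 to compound 3 (0.47 log units; beyond the scatter). For compound 3 the estimated value is 15000 nM, with a range of 5000 nM to 60000 nM.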

Compound 3, solubility: < 5000 nM
Compound 3 gave a limit, no number (the forecaster's own chance of this, stated with the estimate: 30%); middle value at least 3.0-fold (0.47 log units) from the limit.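

In this assay, the large drop no longer belongs to the propyl chain alone: amino in place of hydroxy on the same carbonyl carbon gives an at least 35-fold lower number from compound 1 to compound 3 (1.54 log units; beyond the scatter). Of the three groups now seen on this carbon, only hydroxy, in compound 1, gives a value clear of the limit, and removing the propoxy group did not by itself yield a readable number. Compound 2 and compound 3 each give a limit and not a number, the step between them cannot be read, and any order of propoxy and amino stays unknown: the limit of < 5000 nM in this assay, at which 2 of the 3 values shown sit.

Going by these compounds, how far compound 2 and compound 3 lie past that limit remains open. Also open, on these data alone, is whether a methylamine, a methoxy group or a second carboxylic acid on the shared core would give a readable value.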